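The compounds below may be only part of what the source reports. "The series", "measured", "known", "first", "only" and "open" are said of these compounds alone.

Of the compounds shown here, three have so far been measured in a functional assay on RAW264.7 cells (Mus musculus) for inhibition; on this read-out higher numbers stand for weaker inhibition and lower numbers for stronger inhibition. Compound 1, `O=C1/C(=C/c2cccc(OC(F)(F)F)c2)CCc2cc(O)ccc21`, gives 520 nM in this assay. Compound 2, `O=C1/C(=C/c2cccc(Cl)c2)CCc2cc(O)ccc21`, gives 1750 nM in this assay. Compound 3, `O=C1/C(=C/c2ccccc2OC(F)(F)F)CCc2ccc(O)cc21`, gives 420 nM in this assay. Compound 4, `O=C1/C(=C/c2ccccc2Cl)CCc2ccc(O)cc21`, awaits measurement.

Compound 1 and compound 2 differ in a single place.

chloro in place of trifluoromethoxy on an aromatic carbon

That one change produced a 3.4-fold higher number from compound 1 to compound 2 (0.53 log units; beyond the scatter).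

Compound 3 and compound 1 are built from the same atoms joined differently; the difference between the two cores is not broken down here. Their values in this assay lie within the usual scatter of each other, so no order between them can be read. Compound 2 stands apart from both, beyond the scatter in each case.

Compound 4 is derived from compound 3 by the same kind of change.

chloro in place of trifluoromethoxy on an aromatic carbon

The surroundings are not identical: in compound 2 the chloro sits meta to a large group, whereas in compound 4 it sits ortho to a large group. That difference in place leaves room for the outcome to drift.

Among the compounds with values here, the expected step in this assay is a 3.3-fold higher number from compound 3 to compound 4 (0.52 log units; beyond the scatter), resting on the measured 3.4-fold higher number from compound 1 to compound 2 (0.53 log units; beyond the scatter) as the only guide available. On that basis compound 4 is expected to give about 1400 nM in this assay. Allowing for the changed surroundings, compound 4 is estimated to fall between 500 nM and 4000 nM.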

Compound 4, half-maximal inhibitory concentration: 270 nM
For compound 4 the middle estimate is 5.2-fold (0.71 log units) above the measured one; the measured number lies below the stated range.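

In this assay, the swap of trifluoromethoxy for chloro did not give the same result on the two cores: the same change on two cores in this assay, a 3.4-fold higher number (0.53 log units; beyond the scatter) from compound 1 to compound 2 and a 1.6-fold lower number (0.19 log units; within the scatter) from compound 3 to compound 4, 5.2-fold (0.72 log units) apart, beyond the scatter of two such steps

On the core of compound 3, where the group sits ortho to a large group, the new step is a 1.6-fold lower number from compound 3 to compound 4 (0.19 log units; within the scatter), so this pair cannot be put in order, and the clear step seen on the other core did not reappear here. This does not show why the two steps part, since the two pairs differ both in the core and in where the swapped group sits, and a single pair on each core cannot separate those two differences; it shows only that, for these two pairs, a step measured on one core was a poor guide to the step on the other.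

The compounds shown leave open how chloro and trifluoromethoxy would compare if each were moved to the other place on one and the same core, which would tell the effect of the core from that of the place. They also leave open whether other groups at this place, such as a methoxy, an amine or a carboxylic acid, would follow the step seen on one core, the other, or neither.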